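Swapping the aryl ring on a shared arylamino nitrogen

This account rests on a few compounds, and the source may have more. Where it says the series, first, only, none or still open, it means among the compounds named here.

Among the compounds with values here, compound 2 `CC(C)Cc1ccc(C(C)c2nnc3sc(Nc4ccc(F)cc4)nn23)cc1` stands lowest of the two numbers measured so far: in a functional assay on the whole organism (strain Wistar albino) for inhibition, with Rattus norvegicus as the target, read by paw edema, with a stated time of 4 h, at a dose of 70 mg/kg by the oral route (on this read-out higher numbers stand for more inhibition at the one dose given (going by the name of the read-out) and lower numbers for less inhibition), compound 2 gives 28%, whereas compound 1 `CC(C)Cc1ccc(C(C)c2nnc3sc(-c4ccccc4N)nn23)cc1` gives 57.6%. Within the data shown here, the only step measured, a number 29.6 percentage points lower from compound 1 to compound 2 (beyond the scatter), concerns a different change and does not bear directly on the one at hand. Compound 3 `Cc1ccc(Nc2nn3c(C(C)c4ccc(CC(C)C)cc4)nnc3s2)c(C)c1` differs from compound 2 by 2,4-dimethylphenyl in place of 4-fluorophenyl on a nitrogen on an aromatic ring. Among the measured compounds shown here, with no measured step for such an exchange of one ring for another on the same nitrogen, the step of a number 2 percentage points higher from compound 2 to compound 3 (within the scatter) is expected to remain within the scatter. Compound 3 is therefore estimated at 30%, between 15% and 48%.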

Compound 3, a percentage reported as inhibition, in the whole organism at one dose (the size of the read-out at that dose, not a potency): 53%
Beside the measured number, compound 3's estimate is 23 percentage points below it; measured number above the stated range.
By their numbers in this assay, from the lowest: compound 2; then compounds 3 and 1 (each within the scatter of the next).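

In this assay, the ring on this nitrogen turns out to matter: 2,4-dimethylphenyl in place of 4-fluorophenyl gives a number 25 percentage points higher from compound 2 to compound 3 (beyond the scatter), so one ring exchanged for another at this place can move the read-out beyond the scatter. (2,4-Dimethylphenyl)amino in place of 2-aminophenyl gives a number 4.6 percentage points lower from compound 1 to compound 3 (within the scatter), so those two cannot be told apart here. Nothing at hand explains the difference between the two rings.

Open, going by these compounds, is whether both methyl groups are needed, as a single 4-methylphenyl would show, and how a 4-methoxyphenyl ring on the same nitrogen would read.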